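A benzyl in place of the hydroxymethyl on the piperidine

The source may report more compounds than this note shows. Statements on the series, on what has been measured and on what is new or still open speak of the compounds shown alone.

Three compounds share the same test, a functional assay on SK-N-SH cells (Homo sapiens) for inhibition, read by MTT assay, with a stated time of 72 h, tested at 50 uM; a lower number here means less inhibition of growth, a higher number more inhibition of growth at the concentration tested. Compound 1 `C=CCc1cc(O)c(O)c(CN2CCC(CO)CC2)c1` gives 49.4%. Compound 2 `C#CCOc1ccc(CC=C)cc1O`, which has a different core, gives 88.4%. Compound 3 `C=CCc1cc(O)c(O)c(CN2CCC(CCO)CC2)c1` gives 40.6%. Compound 3 therefore sits within the scatter of compound 1, while compound 2 stands far apart from it, beyond the scatter.

Among the measured compounds shown here, the one measured step that reaches compound 3 is a number 8.8 percentage points lower from compound 1 to compound 3 (within the scatter), and it shows that a small change at the end of this side chain left the read-out essentially where it was.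

The next compound, compound 4 `C=CCc1cc(O)c(O)c(CN2CCC(Cc3ccccc3)CC2)c1`, is not yet measured in this assay . It differs from compound 3 as follows: phenyl in place of hydroxymethyl on a saturated chain carbon bound to a saturated ring carbon. For the measured compounds named here, no measured pair shows a hydroxymethyl giving way to a phenyl, so the only guide is that the earlier change on this same chain carbon stayed within the scatter. On that basis compound 4 is expected to land near compound 3, with a step of a number 9.4 percentage points higher from compound 3 to compound 4 (within the scatter) that need not exceed the scatter. The estimate for compound 4 is 50%, with a range from 30% to 75%.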

Compound 4, percent growth inhibition at one concentration: 83.4%
Estimate against measurement, compound 4: 33.4 percentage points below, and the stated range ends below it.
By their numbers in this assay, from the lowest: compounds 3 and 1 (each within the scatter of the next); then compounds 4 and 2 (each within the scatter of the next).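

In this assay, the group on a saturated chain carbon bound to a saturated ring carbon proves not to be indifferent: the change from 2-hydroxyethyl to benzyl gives a number 42.8 percentage points higher from compound 3 to compound 4 (beyond the scatter), and the comparison with the shorter hydroxyl-bearing side chain gives a number 34 percentage points higher from compound 1 to compound 4 (beyond the scatter). Compound 1 and compound 3 had shown only that the read-out stayed within the scatter when the hydroxyl-bearing chain changed, whereas compound 4 shows that replacing that chain with one carrying an aromatic ring can raise growth inhibition well beyond it. The entering phenyl brings more heavy atoms and an aromatic ring while the hydroxyl's hydrogen-bond donor and acceptor leave, so these differences change together in a single step, and no evidence at hand accounts for the rise.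

From the compounds shown here alone, whether the ring must be aromatic remains open, a question that a cyclohexylmethyl group at this place would address. Also open, going by these compounds, are how a longer chain such as phenethyl would read and whether a methoxy group or a carboxylic acid on the phenyl ring would keep the higher inhibition seen with compound 4.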